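Trifluoromethyl in place of butoxy on the shared core

A few compounds are considered here, and "the series" means these few. Any claim that something is new, unique, unknown or untested is made for them only; others in the source may bear on it.

Among the compounds with values here, in a functional assay on A549 cells (Homo sapiens) for antiproliferative activity, read by MTT assay, with a stated time of 48 h (on this read-out lower numbers stand for stronger inhibition and higher numbers for weaker inhibition), compound 1 (`CCCCCCCCCCCCOc1ccc(C(=O)/C=C/c2c(/C=C/c3ccc(OC)cc3)cc(OC)cc2OC)cc1`) gives 7.9 ug/mL and compound 2 (`CCCCOc1ccc(C(=O)/C=C/c2c(/C=C/c3ccc(OC)cc3)cc(OC)cc2OC)cc1`) gives 8.7 ug/mL, so compound 2 stands within the scatter of its only measured neighbour. Compound 3 (`COc1ccc(/C=C/c2cc(OC)cc(OC)c2/C=C/C(=O)c2ccc(C(F)(F)F)cc2)cc1`) carries trifluoromethyl in place of butoxy on an aromatic carbon, para to a large group: trifluoromethyl in place of butoxy on an aromatic carbon. Within the data shown here, the one measured step, a 1.1-fold higher number from compound 1 to compound 2 (0.04 log units; within the scatter), is hydrogen in place of octyl on the saturated chain, and it keeps the oxygen on the aromatic ring. Among the measured compounds shown here, no measured compound lacks that oxygen or carries trifluoromethyl, so the data offer no direction for this change. With wide uncertainty, the step is therefore expected to be a 1.1-fold lower number from compound 2 to compound 3 (0.04 log units; within the scatter). For compound 3 the estimated value is 8 ug/mL, with an expected range from 3 ug/mL to 20 ug/mL.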

Compound 3, half-maximal inhibitory concentration: 7.8 ug/mL
Estimate against measurement, compound 3: 1.0-fold (0.01 log units) above; low and high end bracket the measured number.
By their numbers in this assay, from the lowest: compounds 3, 1 and 2 (each within the scatter of the next).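

In this assay, replacing butoxy with trifluoromethyl on an aromatic carbon, para to a large group, gives a 1.1-fold lower number from compound 2 to compound 3 (0.05 log units; within the scatter). The earlier step shortened the chain but kept the oxygen on the aromatic ring, whereas this change removes both the chain and that oxygen, and the numbers still lie within the scatter, so among these three compounds neither the oxygen nor the chain is needed for a value of this size. Nothing measured here accounts for why such different groups read alike.

From the compounds shown here alone, it remains open whether an amine or a carboxylic acid on this aromatic carbon would also stay within the scatter of these numbers. Also open, going by these compounds, is whether the same holds with a hydroxy group in place of the methoxy groups on the shared core.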